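From Compound 2 to Compound 3: One Ring Exchanged

The source may report more compounds than this note shows. Statements on the series, on what has been measured and on what is new or still open speak of the compounds shown alone.

Measured so far in a functional assay on V79 cells (Cricetulus griseus) for cytotoxicity, read by colony formation; a higher number here means a weaker inhibitor, a lower number a stronger inhibitor:
- compound 1 `CCNCC1CCN(c2c(F)cc3c(=O)c(C(=O)O)cn(C4CC4)c3c2OC)C1` gives 22 ug/mL; 22 ug/mL (2 entries) in both of its entries
- compound 2 `CCNCC1CCN(c2c(F)cc3c(=O)c(C(=O)O)cn(C4CC4)c3c2C(F)(F)F)C1` gives 120 ug/mL in its single entry

Within the data shown here, only two compounds have been measured, so compound 2 can be placed only against compound 1. Compound 2 has the higher number of the pair, which makes it the weaker inhibitor of the two in this assay.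

Compound 3 `CC1CN(c2c(F)cc3c(=O)c(C(=O)O)cn(C4CC4)c3c2C(F)(F)F)CC(C)N1` keeps the trifluoromethyl group of compound 2 and changes one substituent: 3,5-dimethylpiperazin-1-yl in place of 3-((ethylamino)methyl)pyrrolidin-1-yl on an aromatic carbon. In words, 3,5-dimethylpiperazin-1-yl stands in place of 3-((ethylamino)methyl)pyrrolidin-1-yl on an aromatic carbon, ortho to a fluoro group and ortho to a trifluoromethyl group.

Among the measured compounds shown here, no measured pair shows what this exchange does, so any expectation is uncertain, and a result within the usual scatter of compound 2 remains possible. The estimate starts from compound 2 at 120 ug/mL and leans modestly toward a lower number. The estimate means a 2.0-fold lower number from compound 2 to compound 3 (0.30 log units; within the scatter) as the expected step. For compound 3 the estimated value is 60 ug/mL, with an expected range from 20 ug/mL to 170 ug/mL.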

Compound 3, half-maximal inhibitory concentration: > 500 ug/mL
Compound 3 ended at the assay's limit (the forecaster's own chance of this, stated with the estimate: 10%); middle value at least 8.3-fold (0.92 log units) away from the limit.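

In this assay compound 3 gives > 500 ug/mL, which is a limit of the assay and not a number. Among these compounds, compounds 1 and 2 both carry 3-((ethylamino)methyl)pyrrolidin-1-yl, so they said nothing about this position, on an aromatic carbon ortho to a fluoro group and ortho to a trifluoromethyl group; the exchange for 3,5-dimethylpiperazin-1-yl now gives an at least 4.1-fold higher number from compound 2 to compound 3 (0.61 log units; beyond the scatter), the first sign that the group here matters in this assay, with compound 3 the weaker inhibitor of the pair. The true size of the step stays unknown, and it can be read only as a minimum because the value of compound 3 is a limit: the limit of > 500 ug/mL in this assay, at which 1 of the 3 values shown sits.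

The exchange changes several things at once, a five-membered ring for a six-membered one with a second ring nitrogen and a different set of carbon branches, so the compounds shown cannot tell which of these goes with the step. A plain piperazin-1-yl group without the two methyl groups, or the same 3,5-dimethylpiperazin-1-yl group on the core of compound 1 with its methoxy group, would begin to separate these possibilities.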